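The source may hold more compounds than are shown below. What is called first, only, known or untested is meant among the compounds shown, and "the series" means these compounds.

In a functional assay on the whole organism with Mus musculus as the target, in the rotarod test (on this read-out lower numbers stand for an effect already at smaller amounts and higher numbers for an effect only at larger amounts of compound), compound 2 `CCCCCC(=O)NCC(=O)N(C)c1ccc(Cl)cc1C(=O)c1ccccc1Cl` gives 90 mg/kg, the larger of the two numbers shown, though the gap to the nearest, compound 1 `CCCC(=O)NCC(=O)N(C)c1ccc(Cl)cc1C(=O)c1ccccc1Cl` at 55.2 mg/kg, lies within the scatter. Compound 3 `CC(=O)NCC(=O)Nc1ccc(Cl)cc1C(=O)c1ccccc1` gives only a limit of the assay, > 100 mg/kg. Compound 4 `CN(C(=O)CNC(=O)c1ccccc1)c1ccc(Cl)cc1C(=O)c1ccccc1Cl` differs from compound 2 by phenyl in place of pentyl on a carbonyl carbon. For the measured compounds named here, the one measured step, a 1.6-fold higher number from compound 1 to compound 2 (0.21 log units; within the scatter), bears on it only loosely: it alters the same chain, yet it is a different kind of change from phenyl in place of pentyl, and it lay within the scatter. The limit of > 100 mg/kg in this assay, at which 1 of the 3 values shown sits, gives no direction either. One therefore expects no step beyond the scatter, a 1.3-fold lower number from compound 2 to compound 4 (0.11 log units; within the scatter). Compound 4 is estimated at 70 mg/kg, between 25 mg/kg and 200 mg/kg.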

Compound 4, dose for half-maximal effect: > 100 mg/kg
Compound 4 gave a limit, no number; the forecaster's own chance of this, stated with the estimate: 25%; middle value at least 1.4-fold (0.15 log units) away from the limit.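

In this assay compound 4 gives > 100 mg/kg, which is a limit and not a number. Phenyl in place of pentyl gives an at least 1.1-fold higher number from compound 2 to compound 4 (0.04 log units; that floor lies within the scatter), and phenyl in place of propyl gives an at least 1.8-fold higher number from compound 1 to compound 4 (0.25 log units; that floor lies within the scatter); both floors lie within the scatter, so this carbonyl carbon shows no gain with phenyl and no proven loss. The result adds a second compound at the same limit: the limit of > 100 mg/kg in this assay, at which 2 of the 4 values shown sit.

As far as these compounds go, how far beyond its limit compound 4 lies remains open. Also open, from the compounds shown here alone, is what an amine, a carboxylic acid or a chain longer than pentyl would give at this place.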